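The compounds below may be only part of what the source reports. "The series", "measured", "known", "first", "only" and "open" are said of these compounds alone.

Measured compounds:
Compound 1 `CC(O)(C[S+]([O-])c1ccc(F)cc1F)C(=O)Nc1ccc([N+](=O)[O-])cc1C(F)(F)F`: in a functional assay on VCaP cells (Homo sapiens) for antiproliferative activity (a lower number here means a stronger inhibitor, a higher number a weaker inhibitor), compound 1 gives > 100000 nM, a limit of the assay and not a number.
Compound 2 `CC(O)(C[S+]([O-])c1ccc(C(F)(F)F)cc1)C(=O)Nc1ccc([N+](=O)[O-])cc1C(F)(F)F`: in this assay compound 2 gives 24200 nM.
Compound 3 `CC(O)(C[S+]([O-])c1ccccn1)C(=O)Nc1ccc(C#N)c(C(F)(F)F)c1`: in this assay compound 3 gives > 100000 nM, again a limit of the assay.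

Compound 1 thus stands at the limit, as the limit of > 100000 nM in this assay, at which 2 of the 3 values shown sit, records. Compound 4 `CC(O)(C[S+]([O-])c1ccc(OC(F)(F)F)cc1)C(=O)Nc1ccc([N+](=O)[O-])cc1C(F)(F)F` differs from it in one place: 4-(trifluoromethoxy)phenyl in place of 2,4-difluorophenyl on a sulfur. Among the measured compounds shown here, the only measured step that bears on this change is an at least 4.1-fold lower number from compound 1 to compound 2 (0.61 log units; beyond the scatter), where another para-substituted phenyl also replaced the 2,4-difluorophenyl on the sulfur. A step of similar size and direction is therefore expected for compound 4, namely an at least 3.3-fold lower number from compound 1 to compound 4 (0.52 log units; beyond the scatter). Compound 4 is estimated at 30000 nM, with a range from 8000 nM to 120000 nM.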

Compound 4, half-maximal inhibitory concentration: > 100000 nM
Compound 4: no number, only a limit (the forecaster's own chance of this, stated with the estimate: 35%); middle value at least 3.3-fold (0.52 log units) away from the limit.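

Compound 4 gives > 100000 nM in this assay, a limit of the assay and not a number. On the sulfur, trifluoromethoxy in place of trifluoromethyl on an aromatic carbon gives an at least 4.1-fold higher number from compound 2 to compound 4 (0.61 log units; beyond the scatter), so among these compounds a measurable value depends on the exact group and 4-(trifluoromethyl)phenyl alone reaches one. The step between compound 1 and compound 4 cannot be read, and compound 4 joins the compounds at: the limit of > 100000 nM in this assay, at which 3 of the 4 values shown sit.

As far as these compounds go, it remains open whether a chlorine or a methoxy group on that phenyl ring would give a readable value in this assay.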